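This account rests on a few compounds, and the source may have more. Where it says the series, first, only, none or still open, it means among the compounds named here.

Going by the values given here, in a functional assay on the whole organism with Rattus norvegicus as the target (a higher number here means that more compound is needed for the effect, a lower number that less compound is needed), compound 2 (`CCCSCCn1c(=N)sc2cc(OC(F)(F)F)ccc21`) gives 2.4 mg/kg as the only exact number so far. Compound 1 (`N=c1sc2cc(OC(F)(F)F)ccc2n1CC(=O)O`) gives > 10 mg/kg as a limit of the assay. Compound 3 (`N=c1sc2cc(OC(F)(F)F)ccc2n1CCSc1ccccc1`) differs from compound 2 by phenyl in place of propyl on a sulfur and thus has phenyl in place of propyl on a sulfur. Among the compounds with values here, the only measured step is an at least 4.1-fold lower number from compound 1 to compound 2 (0.61 log units; beyond the scatter) and it installs the sulfur chain without varying the group on the sulfur, so it offers little guidance here. The expected change is a 1.3-fold higher number from compound 2 to compound 3 (0.10 log units; within the scatter) and no clear step in either direction is expected. Compound 3 is expected at 3 mg/kg with an estimated range of 1 mg/kg to 10 mg/kg in this assay.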

Compound 3, dose for half-maximal effect: 4.5 mg/kg
The estimate for compound 3 lay 1.5-fold (0.18 log units) below the measured number; the measured number falls inside the stated range.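

Going by these compounds alone, with phenyl in place of propyl on a sulfur, the group on the sulfur itself changes for the first time, and in this assay the outcome stays within the scatter: a 1.9-fold higher number from compound 2 to compound 3 (0.27 log units; within the scatter). The phenyl-bearing chain also separates from the carboxy group, giving an at least 2.2-fold lower number from compound 1 to compound 3 (0.34 log units; beyond the scatter). Going by these compounds, the full size of that step stays unknown, since compound 1 has only a limit of the assay: the limit of > 10 mg/kg in this assay, at which 1 of the 3 values shown sits. On these data alone, what an amine or a longer chain on the sulfur would do in this assay remains open, as does the effect of a chlorine on the phenyl ring.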